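Ring methyl moved: compound 2 to compound 3 in cytotoxicity

The source may hold more compounds than are shown below. What is called first, only, known or untested is meant among the compounds shown, and "the series" means these compounds.

Compound 1, `COc1cccc(/C=C/C(=O)c2sc(Nc3cccc(C)c3)nc2C)c1`: > 25000 nM in a functional assay on Bel-7402 cells (Homo sapiens) for cytotoxicity, read by MTT assay (a higher number here means a weaker inhibitor, a lower number a stronger inhibitor), a limit of the assay.
Compound 2, `Cc1ccccc1Nc1nc(C)c(C(=O)/C=C/c2ccccc2)s1`: > 25000 nM in this assay, likewise a limit and not a number.

Compound 2 therefore stands only at the limit of > 25000 nM in this assay, at which 2 of the 2 values shown sit, with no measured number for it. Compound 3, `Cc1cccc(Nc2nc(C)c(C(=O)/C=C/c3ccccc3)s2)c1`, differs from compound 2 by 3-methylphenyl in place of 2-methylphenyl on a nitrogen on an aromatic ring, the same atoms joined differently. Going by the values given here, with no measured step between compounds to lean on, and both known values sitting as limits, no change beyond the scatter is expected. Compound 3 is expected at 35000 nM, between 12000 nM and 120000 nM. This means an expected step that the limit leaves unreadable from compound 2 to compound 3.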

Compound 3, half-maximal inhibitory concentration: > 25000 nM
Compound 3 ended at the assay's limit; the forecaster's own chance of this, stated with the estimate: 85%; the middle value does not contradict the limit.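

No step can be read from compound 2 to compound 3 or from compound 1 to compound 3, because each value is a limit and not a number: the limit of > 25000 nM in this assay, at which 3 of the 3 values shown sit.

The compounds shown leave open whether moving the ring methyl or replacing methoxy with hydrogen changes the result in this assay at all.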